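This account rests on a few compounds, and the source may have more. Where it says the series, first, only, none or still open, it means among the compounds named here.

Measured so far:
compound 1, `CC1CC(=O)N(CC(=O)N2CCN(c3ccccc3)CC2)C1=O`: 300 mg/kg
compound 2, `Cc1cccc(N2CCN(C(=O)CN3C(=O)CC(C)C3=O)CC2)c1`: 300 mg/kg
compound 3, `CC1CC(=O)N(CC(=O)N2CCN(c3cccc(Cl)c3)CC2)C1=O`: 100 mg/kg

All three were tested in a functional assay on the whole organism (strain CD1) with Mus musculus as the target, in the maximal electroshock model, with a stated time of 0.5 h; a higher number here means that more compound is needed for the effect, a lower number that less compound is needed. Compound 3 carries the lowest number of the three: the step of a 3.0-fold lower number from compound 1 to compound 3 (0.48 log units; beyond the scatter) and the step of a 3.0-fold lower number from compound 2 to compound 3 (0.48 log units; beyond the scatter) are both beyond the scatter, whereas no change at the digits printed from compound 1 to compound 2 (within the scatter) stays within it. Compound 4, `CC1CC(=O)N(CC(=O)N2CCN(c3ccccc3Cl)CC2)C1=O`, holds the same atoms as compound 3 joined differently: 2-chlorophenyl in place of 3-chlorophenyl on an amine nitrogen in a ring. Going by the values given here, no measured step covers a change of this kind; the two modest steps leading to compound 3 concern only the introduction of chloro on an aromatic carbon, not its relocation. With no direct guide, compound 4 is expected to give back part of that gain, a 2.0-fold higher number from compound 3 to compound 4 (0.30 log units; within the scatter), a step near the edge of the scatter. The estimate for compound 4 in this assay is 200 mg/kg, with a range from 90 mg/kg to 400 mg/kg.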

Compound 4, minimum effective dose: 300 mg/kg
Compound 4: middle estimate off by 1.5-fold (0.18 log units), on the low side; the measured number falls inside the stated range.
By their numbers in this assay, from the lowest: compound 3; then compounds 1, 2 and 4 (each within the scatter of the next).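

In this assay the gain from chloro depends on where it sits, since 2-chlorophenyl in place of 3-chlorophenyl gives a 3.0-fold higher number from compound 3 to compound 4 (0.48 log units; beyond the scatter) and removes the whole gain. The other two steps, no change at the digits printed from compound 1 to compound 4 (within the scatter) and no change at the digits printed from compound 2 to compound 4 (within the scatter), leave 2-chlorophenyl level with phenyl and 3-methylphenyl, so among these four compounds only compound 3 stands apart. Nothing at hand accounts for the gap between the two chlorophenyl groups. Still open, going by these compounds, is whether a trifluoromethyl or methoxy group in place of the chloro of compound 3 would keep the gain, and whether a second chloro on the same ring would add to it.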